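A few compounds are considered here, and "the series" means these few. Any claim that something is new, unique, unknown or untested is made for them only; others in the source may bear on it.

Measured so far:
Compound 1, `CCc1ccc(NC(=O)Nc2cc(C)nc3ccccc23)cc1`: > 25000 nM in an ADME assay on Raji cells (Homo sapiens) for cytotoxicity, with a stated time of 72 h (on this read-out higher numbers stand for an effect only at larger amounts of compound and lower numbers for an effect already at smaller amounts), which is a limit of the assay rather than a number.
Compound 2, `Cc1ccc(NC(=O)Nc2cc(C)nc3ccccc23)cc1`: > 25000 nM in this assay, again a limit of the assay rather than a number.

The two compounds share one core and differ only in a side group. The step from the first to the second, a step that the two limits leave unreadable from compound 1 to compound 2, cannot be read, because the limit of > 25000 nM in this assay, at which 2 of the 2 values shown sit: neither compound reached an effect within the tested range. Compound 2 therefore stands only at a limit in this assay, with no number of its own.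

The unmeasured compound 3, `Cc1cc(NC(=O)Nc2ccccc2F)c2ccccc2n1`, differs from compound 2 by 2-fluorophenyl in place of 4-methylphenyl on an amide-type nitrogen. No measured step bears on this exchange: the single step shown is unreadable, and it concerns a different part of the molecule. The expectation for compound 3 thus rests on the shared core alone, which gave only limits in both cases, so a step of no size beyond the scatter, a step that the limit leaves unreadable from compound 2 to compound 3, is expected. Compound 3 is estimated to give 40000 nM, between 10000 nM and 200000 nM, most likely again as a limit.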

Compound 3, half-maximal effective concentration: > 25000 nM
Compound 3: a limit, no number; the forecaster's own chance of this, stated with the estimate: 80%; the middle value lies beyond the limit too.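

The exchange of 4-methylphenyl for 2-fluorophenyl gives no readable step from compound 2 to compound 3, because both stand at a limit of the assay rather than at a number: the limit of > 25000 nM in this assay, at which 3 of the 3 values shown sit.

The compounds shown leave open whether any side group on the shared core can give a measurable value in this assay.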